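Benzyl exchange on compound 2 and its expected outcome

The source may hold more compounds than are shown below. What is called first, only, known or untested is meant among the compounds shown, and "the series" means these compounds.

Within the data shown here, the series so far holds two measured amides, compound 1 `COc1ccc(Cn2cc(CNC(=O)c3cn(-c4ccccc4)nc3-c3ccc(F)cc3)nn2)cc1OC` and compound 2 `COc1ccc(-c2nn(-c3ccccc3)cc2C(=O)NCc2cn(Cc3ccc(C(F)(F)F)cc3)nn2)cc1`, both tested in a functional assay on MCF7 cells (Homo sapiens) for antiproliferative activity, read by sulforhodamine B assay, with a stated time of 48 h; on this read-out lower numbers stand for stronger inhibition of growth and higher numbers for weaker inhibition of growth. Compound 1 returns only a limit, > 100000 nM. Compound 2 likewise returns only a limit, > 100000 nM. Where compound 2 stands is therefore known only as a limit, and the single further value shown sits at that same limit (the limit of > 100000 nM in this assay, at which 2 of the 2 values shown sit); no numbered step between measured compounds exists in this set.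

Compound 3 `COc1ccc(-c2nn(-c3ccccc3)cc2C(=O)NCc2cn(Cc3ccc(OC)c(OC)c3)nn2)cc1` is not yet measured. It differs from compound 2 in one place: 3,4-dimethoxyphenyl in place of 4-(trifluoromethyl)phenyl on a saturated chain carbon bound to an aromatic nitrogen. Compound 1 already carries 3,4-dimethoxyphenyl on a saturated chain carbon bound to an aromatic nitrogen, and its reading in this assay is the limit > 100000 nM, so the change offers no sign of a gain. The step from compound 2 to compound 3 is expected to be none beyond the scatter, a number no higher from compound 2 to compound 3 (the limit leaves the size open), with a high chance that only a limit is reported again. Compound 3 is estimated at 100000 nM, within 30000 nM to 300000 nM.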

Compound 3, concentration for 50% growth inhibition: > 100000 nM
Compound 3: no number, only a limit; the forecaster's own chance of this, stated with the estimate: 85%; the middle value sits exactly at the limit.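

No step can be read for compound 3 against compound 2 or compound 1 in this assay, because all three readings are limits: the limit of > 100000 nM in this assay, at which 3 of the 3 values shown sit.

The compounds shown leave open whether any change on the shared core gives a number rather than a limit, and how 3,4-dimethoxybenzyl and 4-(trifluoromethyl)benzyl compare.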